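Toward an Amino Group on the Aromatic Ring

A few compounds are considered here, and "the series" means these few. Any claim that something is new, unique, unknown or untested is made for them only; others in the source may bear on it.

Of the compounds shown here, three sharing one core have been measured in a functional assay (muscle tissue) with Cavia porcellus as the target; a lower number here means that less compound is needed, a higher number that more compound is needed for the effect. Compound 1 `COC(=O)C1=C(C)N=C(C)/C(=C(\O)OC)C1c1ccc(Cl)cc1` gives 8130 nM. Compound 2 `COC(=O)C1=C(C)N=C(C)/C(=C(\O)OC)C1c1cccc(OC(C)=O)c1` gives 6030 nM. Compound 3 `COC(=O)C1=C(C)N=C(C)/C(=C(\O)OC)C1c1cccc(OC(=O)c2ccccc2)c1` gives 6310 nM, which places it second highest of the three numbers, with compound 2 nearest and compound 1 furthest, both within the scatter. Going by the values given here, the only step between direct neighbours, a 1.0-fold higher number from compound 2 to compound 3 (0.02 log units; within the scatter), put phenyl in place of methyl on a carbonyl carbon and left the number where it was.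

Compound 4 `COC(=O)C1=C(C)N=C(C)/C(=C(\O)OC)C1c1cccc(N)c1` differs from compound 3 in that (amino in place of benzoyloxy on an aromatic carbon). Among the compounds with values here, no measured step exchanges a benzoyloxy group for an amino group, so the closest guide is the observation that compounds 1, 2 and 3 carry different groups on the aromatic ring yet all sit within the scatter of one another. The account therefore expects a 1.1-fold lower number from compound 3 to compound 4 (0.02 log units; within the scatter) to remain within the scatter. Compound 4 is estimated at 6000 nM, with a range from 2000 nM to 18000 nM.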

Compound 4, half-maximal effective concentration: 2000 nM
Beside the measured number, compound 4's estimate is 3.0-fold (0.48 log units) above it, and the stated range covers the measured number.
By their numbers in this assay, from the lowest: compound 4; then compounds 2, 3 and 1 (each within the scatter of the next).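

In this assay, going by these compounds alone, this aromatic carbon turns out to respond to the group it carries: amino in place of benzoyloxy (a 3.2-fold lower number from compound 3 to compound 4 (0.50 log units; beyond the scatter)) and amino in place of acetoxy (a 3.0-fold lower number from compound 2 to compound 4 (0.48 log units; beyond the scatter)) are the first steps to go beyond the scatter, whereas the earlier change on the carbonyl carbon stayed within it. The step to 3-aminophenyl in place of 4-chlorophenyl (a 4.1-fold lower number from compound 1 to compound 4 (0.61 log units; beyond the scatter)) points the same way, although it changes both the group and where it sits on the ring, so it cannot separate the two. Nothing available explains why the amino group gives the lower number.

On these data alone, whether the lower number is specific to a free amino group, or would also appear with a methylamino, acetamido or hydroxyl group on the same carbon, remains open. Also open, as far as these compounds go, is whether an amino group would give a similar number at the ring carbon that holds the chlorine in compound 1.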